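Moving the fluorine on the hydrazone aryl ring

This account rests on a few compounds, and the source may have more. Where it says the series, first, only, none or still open, it means among the compounds named here.

Compound 2, `CN(C)C/C=C/C(=O)Nc1cccc(Nc2nc(N/N=C/c3ccccc3F)ncc2Cl)c1`, carries a dimethylamino-butenamide on the aniline and a 2-fluorophenyl on the hydrazone carbon. For the measured compounds named here, in an ADME assay on HT-29 cells (Homo sapiens) for inhibition, read by MTT assay, with a stated time of 72 h (a lower number here means a stronger inhibitor, a higher number a weaker inhibitor), compound 2 gives 3660 nM, the lowest of the two numbers so far. The other measured member, compound 1, `Nc1cccc(Nc2nc(N/N=C/c3ccc(F)cc3)ncc2Cl)c1`, has a free amine on the aniline and a 4-fluorophenyl on the hydrazone carbon, and in this assay compound 1 gives 12300 nM, a number above that of compound 2 by a margin beyond the scatter. Compounds 1 and 2 differ in two places at once. No single step can be read from them.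

Compound 3, `CN(C)C/C=C/C(=O)Nc1cccc(Nc2nc(N/N=C/c3ccc(F)cc3)ncc2Cl)c1`, differs from compound 2 in one place only: 4-fluorophenyl in place of 2-fluorophenyl on a carbon with a double bond to nitrogen. Compound 3 thus combines the aniline substituent of compound 2 with the aryl ring of compound 1. Going by the values given here, with no step of this kind measured, a small change, or none beyond the scatter, is the expectation for this assay. Compound 3 is therefore estimated to give 4000 nM, with a range of 1500 nM to 11000 nM, a step of a 1.1-fold higher number from compound 2 to compound 3 (0.04 log units; within the scatter) that is expected to stay close to compound 2.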

Compound 3, half-maximal inhibitory concentration: 3300 nM
Estimate against measurement, compound 3: 1.2-fold (0.08 log units) above; the range from low to high includes it.
By their numbers in this assay, from the lowest: compounds 3 and 2 (each within the scatter of the next); then compound 1.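

In this assay, 4-fluorophenyl in place of 2-fluorophenyl on a carbon with a double bond to nitrogen gives a 1.1-fold lower number from compound 2 to compound 3 (0.04 log units; within the scatter), so with the dimethylamino-butenamide in place, the two fluorophenyl groups cannot be told apart at this position. The earlier pair differed in two places at once, but a single change on the aniline can now be read with the 4-fluorophenyl held fixed: (3-(dimethylamino)prop-1-en-1-yl)carbonyl in place of hydrogen on a nitrogen on an aromatic ring gives a 3.7-fold lower number from compound 1 to compound 3 (0.57 log units; beyond the scatter), a modest step beyond the scatter, and so the gap between the first two compounds tracks the change on the aniline rather than the place of the fluorine. No supporting measurement is available to explain either step.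

The compounds shown leave open whether the fluorine matters at all, since an unsubstituted phenyl, a chlorophenyl or a methoxyphenyl on that carbon would be needed to say. They also leave open which part of the aniline substituent goes with the step, as a plain acryloyl group or a saturated butanoyl chain carrying the same dimethylamino group would separate the double bond from the amine.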